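A Chlorofluorophenyl Swap on a Sulfonamide Nitrogen

The source may hold more compounds than are shown below. What is called first, only, known or untested is meant among the compounds shown, and "the series" means these compounds.

Compound 1 `O=S(=O)(Nc1cccc(Cl)c1)c1ccc(-c2cnc(C3CC3)o2)cc1` gives > 100000 nM as a limit
Compound 2 `Cc1cc(NS(=O)(=O)c2ccc(-c3cnc(C4CC4)o3)cc2)ccc1Cl` gives > 100000 nM as a limit
Compound 3 `O=S(=O)(Nc1ccc(F)cc1F)c1ccc(-c2cnc(C3CC3)o2)cc1` gives > 100000 nM as a limit

Compound 3 stands at > 100000 nM in a functional assay on cells (leukaemia cell line, Homo sapiens) for inhibition, read by sulforhodamine B assay, with a stated time of 48 h (on this read-out higher numbers stand for lower toxicity in this test and lower numbers for higher toxicity in this test), and this is a limit, not a number. The same holds across the series, with the limit of > 100000 nM in this assay, at which 3 of the 3 values shown sit, as the whole record so far. Compound 4 `O=S(=O)(Nc1cc(F)cc(Cl)c1)c1ccc(-c2cnc(C3CC3)o2)cc1` brings one change, 3-chloro-5-fluorophenyl in place of 2,4-difluorophenyl on a sulfonamide nitrogen on a sulfonamide nitrogen. The steps a step that the two limits leave unreadable from compound 1 to compound 3 and a step that the two limits leave unreadable from compound 2 to compound 3 bear on it, yet neither has a size that can be read. Because compound 3 sits at > 100000 nM as a limit, no step beyond the scatter is expected, in either direction. The estimated step is a number no higher from compound 3 to compound 4 (the limit leaves the size open) in size. For compound 4 the expected value is 100000 nM with an estimated range from 40000 nM to 200000 nM in this read-out.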

Compound 4, concentration lethal to 50% of the cells: > 100000 nM
Compound 4: no number, only a limit (the forecaster's own chance of this, stated with the estimate: 85%); the middle value lies on the limit itself.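

No step from compound 1, compound 2 or compound 3 to compound 4 can be read in this assay, and all four values are limits: the limit of > 100000 nM in this assay, at which 4 of the 4 values shown sit.

The compounds shown leave open whether these phenyl groups on a sulfonamide nitrogen differ at all in this assay.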